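A few compounds are considered here, and "the series" means these few. Any claim that something is new, unique, unknown or untested is made for them only; others in the source may bear on it.

In a functional assay on MDA-MB-231 cells (Homo sapiens) for antiproliferative activity, read by sulforhodamine B assay, with a stated time of 72 h (a lower number here means a stronger inhibitor, a higher number a weaker inhibitor), compound 1 (`CC(C)C[C@H](NC(=O)CSc1cc(NS(=O)(=O)c2ccccc2)c2ccccc2c1O)B(O)O`) gives 10600 nM and compound 2 (`CC(C)C[C@H](NC(=O)CSc1cc(NS(=O)(=O)c2cccs2)c2ccccc2c1O)B(O)O`) gives 6520 nM, so compound 2 stands level with compound 1: a 1.6-fold lower number from compound 1 to compound 2 (0.21 log units; within the scatter). Compound 4 (`CC(C)C[C@H](NC(=O)C(C)Sc1cc(NS(=O)(=O)c2cccs2)c2ccccc2c1O)B(O)O`) departs from compound 2 by methyl in place of hydrogen on a saturated chain carbon bound to a carbonyl carbon and a sulfur. Among the compounds with values here, no measured step isolates this change, and the step to compound 2 from compound 1 lies elsewhere. The nearest guide is compound 3 (`CC(C)C[C@H](NC(=O)C(C)Sc1cc(NS(=O)(=O)c2ccc(Cl)cc2)c2ccccc2c1O)B(O)O`), which carries that methyl with a different group on the sulfonyl sulfur and gives 6150 nM; 6460 nM (2 entries), close to the value of compound 2. The expected step, a 1.1-fold lower number from compound 2 to compound 4 (0.04 log units; within the scatter), therefore stays within the scatter, in no particular direction. Compound 4 is estimated at 6000 nM, with an expected range of 3000 nM to 12000 nM.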

Compound 4, half-maximal inhibitory concentration: 7450 nM
Estimate against measurement, compound 4: 1.2-fold (0.09 log units) below; measured number inside the range.
By their numbers in this assay, from the lowest: compounds 2, 4 and 1 (each within the scatter of the next).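

In this assay, methyl in place of hydrogen on a saturated chain carbon bound to a carbonyl carbon and a sulfur gives a 1.1-fold higher number from compound 2 to compound 4 (0.06 log units; within the scatter). Within the data shown here, this is the first direct reading of that change, since compound 3 carried the methyl only with a different group on the sulfonyl sulfur, and it shows that this one methyl leaves the number within the scatter. Nothing given here speaks to why the step is so small.

From the compounds shown here alone, whether an ethyl group or a carboxylic acid at this carbon would also leave the number in place remains open. So does whether the methyl step holds with phenyl on the sulfonyl sulfur.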